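Swapping a Bromobenzyl Group for an Allyl Chain

A few compounds are considered here, and "the series" means these few. Any claim that something is new, unique, unknown or untested is made for them only; others in the source may bear on it.

Two compounds have been measured in a functional assay on MGC-803 cells (Homo sapiens) for inhibition, read by MTT assay, with a stated time of 72 h; a lower number here means a stronger inhibitor, a higher number a weaker inhibitor:
compound 1 `Cc1cc(Nc2cc(-c3ccccc3)[nH]n2)n2nc(SCc3ccc(F)cc3)nc2n1` gives 3270 nM;
compound 2 `Cc1cc(Nc2cc(-c3ccccc3)[nH]n2)n2nc(SCc3ccccc3Br)nc2n1` gives 3650 nM.

Compound 2 stands beside compound 1, with the step of a 1.1-fold higher number from compound 1 to compound 2 (0.05 log units; within the scatter) lying within the scatter, so the two are level. Compound 3 `C=CCSc1nc2nc(C)cc(Nc3cc(-c4ccccc4)[nH]n3)n2n1` differs from compound 2 by vinyl in place of 2-bromophenyl on a saturated chain carbon bound to a sulfur. Among the measured compounds shown here, the single measured step exchanged one aromatic ring for another and changed little; nothing measured shows what removing the ring altogether does, so the expectation rests on compound 2 alone. For compound 3 a modest weakening is expected, a 1.5-fold higher number from compound 2 to compound 3 (0.18 log units; within the scatter). Compound 3 is thus estimated at 5500 nM, with a range of 2000 nM to 15000 nM.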

Compound 3, half-maximal inhibitory concentration: 17200 nM
For compound 3 the middle estimate is 3.1-fold (0.50 log units) below the measured one, and the stated range ends below it.
By their numbers in this assay, from the lowest: compounds 1 and 2 (each within the scatter of the next); then compound 3.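

In this assay vinyl in place of 2-bromophenyl gives a 4.7-fold higher number from compound 2 to compound 3 (0.67 log units; beyond the scatter) and vinyl in place of 4-fluorophenyl gives a 5.3-fold higher number from compound 1 to compound 3 (0.72 log units; beyond the scatter) on the same saturated chain carbon bound to a sulfur. Exchanging one aromatic ring for another stayed within the scatter, whereas losing the ring goes beyond it, so this position does respond to the change, and the inhibitor becomes weaker. No available evidence bears on the cause.

As far as these compounds go, whether the ring itself or simply the size of the group matters stays open. An unsubstituted benzyl, a longer chain such as hexyl, or an amine here could help separate these readings.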